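A Side-Chain Swap on a Shared Core

A few compounds are considered here, and "the series" means these few. Any claim that something is new, unique, unknown or untested is made for them only; others in the source may bear on it.

Of the compounds shown here, three with the same core have been tested in a functional assay on A-375 cells (Homo sapiens) for cytotoxicity, read by MTT assay, with a stated time of 72 h; a lower number here means a stronger inhibitor, a higher number a weaker inhibitor. Compound 1 `CN(C)CCCCCn1c2c(c3ccccc31)C(=O)c1c[n+]([O-])c3ccccc3c1C2=O` gives 560 nM, compound 2 `O=C1c2c[n+]([O-])c3ccccc3c2C(=O)c2c1c1ccccc1n2CCCCn1ccnc1` gives 350 nM, and compound 3 `O=C1c2c[n+]([O-])c3ccccc3c2C(=O)c2c1c1ccccc1n2Cc1cn(CC(O)CO)nn1` gives 440 nM. Compound 3 therefore lies within the scatter of both of the others, and these numbers do not rank the three.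

Compound 4 `O=C1c2c[n+]([O-])c3ccccc3c2C(=O)c2c1c1ccccc1n2CCN1CCCC1` has not been measured yet. It keeps the core but carries (pyrrolidin-1-yl)methyl in place of 1-(2,3-dihydroxypropyl)-1H-1,2,3-triazol-4-yl on a saturated chain carbon bound to an aromatic nitrogen.

The closest evidence comes from the side-chain changes already measured. They show a 1.6-fold lower number from compound 1 to compound 2 (0.20 log units; within the scatter), a 1.3-fold lower number from compound 1 to compound 3 (0.10 log units; within the scatter) and a 1.3-fold higher number from compound 2 to compound 3 (0.10 log units; within the scatter). All three steps are small and within the scatter, even though the side chains differ considerably. From the compounds shown here alone, compound 1, which ends in a dimethylamino group, offers the nearest comparison, but none of the three compounds contains the pyrrolidine ring, so that group remains untested. No step beyond the scatter is therefore expected in this assay, in either direction. The expected step is a 1.1-fold lower number from compound 3 to compound 4 (0.04 log units; within the scatter).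

For compound 4 the estimated value is 400 nM, with an expected range from 150 nM to 1000 nM.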

Compound 4, half-maximal inhibitory concentration: 430 nM
For compound 4 the middle estimate is 1.1-fold (0.03 log units) below the measured one; the measured number falls inside the stated range.
By their numbers in this assay, from the lowest: compounds 2, 4, 3 and 1 (each within the scatter of the next).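

In this assay, replacing (1-(2,3-dihydroxypropyl)-1H-1,2,3-triazol-4-yl)methyl with 2-(pyrrolidin-1-yl)ethyl removes the aromatic triazole ring and all the hydrogen-bond donors of the side chain, yet the step is negligible (a 1.0-fold lower number from compound 3 to compound 4 (0.01 log units; within the scatter)). Among these compounds, the pyrrolidine ring, a type of group absent from the earlier compounds, also stays within the scatter of the imidazole of compound 2 (a 1.2-fold higher number from compound 2 to compound 4 (0.09 log units; within the scatter)) and the dimethylamino group of compound 1 (a 1.3-fold lower number from compound 1 to compound 4 (0.11 log units; within the scatter)), so four quite different side chains on the aromatic nitrogen now give numbers that cannot be told apart in this assay. Nothing available explains this flat result, or shows whether the shared core alone sets the level of cytotoxicity.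

What the compounds shown leave open is whether any group at this position can move the number beyond the scatter, in either direction. A carboxylic acid at the end of the chain, a plain hexyl chain with no nitrogen or ring, or a morpholine ring in place of the pyrrolidine would each test that limit.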